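Swapping a Sulfonamide for a Sulfone on the Shared Core

The source may hold more compounds than are shown below. What is called first, only, known or untested is meant among the compounds shown, and "the series" means these compounds.

Compound 2 `CCNS(=O)(=O)c1ccc2c(c1)C(n1ccccc1=O)=CC(C)(C)O2` gives 72.4% in a functional assay on the whole organism (aorta) with Rattus norvegicus as the target; a higher number here means a larger maximal response, a lower number a smaller maximal response. Within the data shown here, the only other measurement comes from compound 1 `CC1(C)C=C(n2ccccc2=O)c2cc(S(N)(=O)=O)ccc2O1`, which gives 77.5%, and the step of a number 5.1 percentage points lower from compound 1 to compound 2 (within the scatter) stays within the scatter. Compound 3 `CC1(C)C=C(n2ccccc2=O)c2cc(S(=O)(=O)c3ccccc3)ccc2O1` differs from compound 2 by phenyl in place of ethylamino on a sulfonyl sulfur. Among the measured compounds shown here, the one measured step, ethyl in place of hydrogen on a sulfonamide nitrogen, barely moved the maximal response, and it bears only loosely on this change, which takes away the hydrogen-bond donor entirely. The step expected here, a number 0.4 percentage points lower from compound 2 to compound 3 (within the scatter), is one within the scatter. Compound 3 is estimated at 72%, between 55% and 88%.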

Compound 3, largest response reached (Emax), in percent of the reference or control that the assay uses: 79.3%
Compound 3: middle estimate off by 7.3 percentage points, on the low side; measured number inside the range.
By their numbers in this assay, from the lowest: compounds 2, 1 and 3 (each within the scatter of the next).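

Phenyl in place of ethylamino on a sulfonyl sulfur gives a number 6.9 percentage points higher from compound 2 to compound 3 (within the scatter) in this assay and phenyl in place of amino gives a number 1.8 percentage points higher from compound 1 to compound 3 (within the scatter) in the same measure. This place on the shared core therefore takes a six-membered aromatic ring with no hydrogen-bond donor, and the maximal response stays within the scatter of both sulfonamides. Nothing available explains this result. Still open, from the compounds shown here alone, is whether a methyl group or a carboxylic acid at this sulfonyl sulfur would also keep the response in this range.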